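A Pyridine in Place of a Thiazole on Compound 2

The source may hold more compounds than are shown below. What is called first, only, known or untested is meant among the compounds shown, and "the series" means these compounds.

Of the compounds shown here, three that share one core have been tested in an ADME assay on Vero cells (Chlorocebus sabaeus) for cytotoxicity, read by MTT assay, with a stated time of 96 h; a higher number here means that more compound is tolerated, a lower number that less compound is tolerated. Compound 1 `COc1ccc(CNc2ccc(-c3cnco3)c(OC)c2)cc1` gives 23900 nM. Compound 2 `COc1cc(NCc2scnc2C)ccc1-c1cnco1` gives 73700 nM, and compound 3 `COc1cc(/N=C/c2ccc(F)cc2)ccc1-c1cnco1` gives 325000 nM. Among these three numbers compound 2 stands second highest: its nearest neighbour is compound 1, whose number is lower by more than the usual scatter, and its furthest is compound 3, whose number is higher, again by more than the scatter. No two of these compounds differ in just one place, so no single measured step links them, and the numbers can only be compared as they stand.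

Compound 4 `COc1cc(NCc2ccncc2)ccc1-c1cnco1` has not yet been measured in this assay. It differs from compound 2 in one place: pyridin-4-yl in place of 4-methyl-1,3-thiazol-5-yl on a saturated chain carbon bound to a nitrogen on an aromatic ring. The group leaving and the group entering are alike in size, as the counted difference shows, and nothing measured here tells how such a swap moves the number. The step from compound 2 to compound 4 is therefore expected to be small, a 1.3-fold lower number from compound 2 to compound 4 (0.13 log units; within the scatter), with no firm direction and possibly none beyond the scatter. Compound 4 is estimated at 55000 nM, with a range from 15000 nM to 200000 nM.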

Compound 4, half-maximal cytotoxic concentration: 342000 nM
The estimate for compound 4 lay 6.2-fold (0.79 log units) below the measured number; the whole stated range lies below it.
By their numbers in this assay, from the lowest: compound 1; then compound 2; then compounds 3 and 4 (each within the scatter of the next).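

Within the data shown here, this is the first step in the set that changes only one place, and it shows that the group on this saturated chain carbon can matter in this assay: pyridin-4-yl in place of 4-methyl-1,3-thiazol-5-yl gives a 4.6-fold higher number from compound 2 to compound 4 (0.67 log units; beyond the scatter). Both groups have the same count of heavy atoms, so in this place a change that leaves that count untouched can still move the number beyond the scatter, here towards more compound being tolerated. Nothing available here explains why the number moves.

This single step cannot show which part of the change matters, since the ring size, the sulfur and the methyl all differ at once; a thiazol-5-yl without the methyl, a pyridin-3-yl or a plain phenyl in the same place would help to separate these differences. The compounds shown also leave open whether a saturated ring carrying an amine, such as piperidin-4-yl, or a longer chain leading to the pyridine would keep the number as high as in compound 4.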